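Pyridin-2-yl for methoxyphenyl on a triazole-bearing core

The compounds below may be only part of what the source reports. "The series", "measured", "known", "first", "only" and "open" are said of these compounds alone.

Measured compounds:
compound 1 `C=C1C[C@]23C[C@@]1(O)CC[C@H]2c1ccc(OS(=O)(=O)c2ccc(C)cc2)c(C)c1[C@@H]3Cn1cc(-c2ccc(OC)cc2)nn1` — > 20000 nM
compound 2 `C=C1C[C@]23C[C@@]1(O)CC[C@H]2c1cc(Br)c(O)c(C)c1[C@@H]3Cn1cc(-c2ccccn2)nn1` — > 20000 nM
compound 3 `C=C1C[C@]23C[C@@]1(O)CC[C@H]2c1ccc(O)c(C)c1[C@@H]3Cn1cc(-c2ccc(OC)cc2)nn1` — > 20000 nM

In a functional assay on HL-60 cells (Homo sapiens) for cytotoxicity, read by MTT assay, with a stated time of 4 days (a lower number here means a stronger inhibitor, a higher number a weaker inhibitor), compound 3 gives > 20000 nM, which is a limit of the assay and not a number. For compound 1 the value > 20000 nM is likewise a limit. For compound 2 the value > 20000 nM is a limit as well. Compound 3 therefore stands at the same limit as the other two measured compounds, and nothing among the numbers shown separates it from them: the limit of > 20000 nM in this assay, at which 3 of the 3 values shown sit.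

Compound 4 `C=C1C[C@]23C[C@@]1(O)CC[C@H]2c1ccc(O)c(C)c1[C@@H]3Cn1cc(-c2ccccn2)nn1` is not yet measured. It differs from compound 3 in one place: pyridin-2-yl in place of 4-methoxyphenyl on an aromatic carbon. Within the data shown here, the only measured step with a single change is a step that the two limits leave unreadable from compound 1 to compound 3, and since both of its ends are limits its size cannot be read. Among the measured compounds shown here, compound 2 also carries pyridin-2-yl, but it differs from compound 4 in a bromine on the aromatic ring, so its limit shows only that a pyridin-2-yl compound of this core sat at the limit as well.

No readable step bears on the change from compound 3 to compound 4, so the expected step that the limit leaves unreadable from compound 3 to compound 4 is none beyond the scatter, and compound 4 is estimated to stay at the limit, at about 30000 nM, between 12000 nM and 100000 nM.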

Compound 4, half-maximal inhibitory concentration: > 20000 nM
Compound 4: a limit, no number (the forecaster's own chance of this, stated with the estimate: 85%); the middle value does not contradict the limit.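

No new step can be read from compound 4: its steps from compound 3 and from compound 2 both join two limits, so neither has a readable size, and all four compounds stand together at one limit: the limit of > 20000 nM in this assay, at which 4 of the 4 values shown sit.

The compounds shown leave open how strongly any of them acts on these cells, and whether pyridin-2-yl, 4-methoxyphenyl or bromo makes any difference on the shared core.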